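The source may hold more compounds than are shown below. What is called first, only, known or untested is meant among the compounds shown, and "the series" means these compounds.

In a functional assay on aorta (strain Wistar) for inhibition, with Thoracic aorta (Rattus norvegicus) as the target (a lower number here means a stronger inhibitor, a higher number a weaker inhibitor), compound 2 `CCOc1nc(-c2cc3ccccc3o2)cc(-c2ccc(Br)cc2)c1C#N` gives 227000 nM. Among the compounds with values here, the only other compound measured, compound 1 `CCOc1nc(-c2cc3ccccc3o2)cc(-c2ccc(Cl)cc2)c1C#N`, gives 221000 nM in this assay, and the two numbers lie within the scatter of each other. Within the data shown here, the single measured step, a 1.0-fold higher number from compound 1 to compound 2 (0.01 log units; within the scatter), swaps one halogen for another without moving the number. Compound 3 `CCOc1nc(-c2cc3ccccc3o2)cc(-c2ccc(C)cc2)c1C#N` differs from compound 2 by methyl in place of bromo on an aromatic carbon. Among the measured compounds shown here, no measured step covers a methyl entering here, and the one step known shows that exchanging a group at this position left the number unchanged, so the expected step is a 1.0-fold lower number from compound 2 to compound 3 (0.01 log units; within the scatter), none beyond the scatter. Compound 3 is therefore estimated at 220000 nM, in a range from 100000 nM to 480000 nM.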

Compound 3, half-maximal inhibitory concentration: 290000 nM
For compound 3 the middle estimate is 1.3-fold (0.12 log units) below the measured one; measured number inside the range.
By their numbers in this assay, from the lowest: compounds 1, 2 and 3 (each within the scatter of the next).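

The earlier pair only swapped one halogen for another, whereas compound 3 puts a carbon group in that place, turning 4-bromophenyl into 4-methylphenyl. This gives a 1.3-fold higher number from compound 2 to compound 3 (0.11 log units; within the scatter), and replacing chloro gives a 1.3-fold higher number from compound 1 to compound 3 (0.12 log units; within the scatter), so at this position methyl is not told apart from either halogen in these numbers. No measurement is available to explain this result. As far as these compounds go, whether an amine, a carboxylic acid or a longer chain here would move the number beyond the scatter stays open, as do changes elsewhere on the shared core.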